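Swapping the aryl group on the core: from compound 3 to compound 4

The source may report more compounds than this note shows. Statements on the series, on what has been measured and on what is new or still open speak of the compounds shown alone.

In a functional assay on HepG2 cells (Homo sapiens) for cytotoxicity, read by MTT assay, with a stated time of 48 h (on this read-out higher numbers stand for weaker inhibition and lower numbers for stronger inhibition), compound 3 `Cc1ncc([N+](=O)[O-])n1CCSc1nnc(-c2ccccc2O)o1` gives 19600 nM, the highest of the three numbers measured. Compound 1 `COc1ccc(-c2nnc(SCCn3c([N+](=O)[O-])cnc3C)o2)cc1` gives 5800 nM and compound 2 `Cc1ncc([N+](=O)[O-])n1CCSc1nnc(-c2ccccc2F)o1` gives 3700 nM. Compound 4 `Cc1ncc([N+](=O)[O-])n1CCSc1nnc(-c2ccc(N)nc2)o1` differs from compound 3 by 6-aminopyridin-3-yl in place of 2-hydroxyphenyl on an aromatic carbon. For the measured compounds named here, the steps that bear on this change are those at the same aryl group: a 3.4-fold higher number from compound 1 to compound 3 (0.53 log units; beyond the scatter) and a 5.3-fold higher number from compound 2 to compound 3 (0.72 log units; beyond the scatter), both modest, while a 1.6-fold lower number from compound 1 to compound 2 (0.20 log units; within the scatter). Going by the values given here, no measured step introduces a 6-aminopyridin-3-yl group, so the direction is uncertain; a modest step in either direction, or none beyond the scatter, is expected. Compound 4 is estimated at 12000 nM, between 4000 nM and 36000 nM, which would mean a step of a 1.6-fold lower number from compound 3 to compound 4 (0.21 log units; within the scatter).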

Compound 4, half-maximal inhibitory concentration: 9400 nM
Beside the measured number, compound 4's estimate is 1.3-fold (0.11 log units) above it, within the range that was stated.
By their numbers in this assay, from the lowest: compounds 2, 1 and 4 (each within the scatter of the next, the first and the last beyond it); then compound 3.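

In this assay the 6-aminopyridin-3-yl group gives a 2.1-fold lower number from compound 3 to compound 4 (0.32 log units; beyond the scatter) and also a 2.5-fold higher number from compound 2 to compound 4 (0.40 log units; beyond the scatter) but only a 1.6-fold higher number from compound 1 to compound 4 (0.21 log units; within the scatter) at this position. A six-membered aromatic ring with a hetero atom therefore leaves the number inside the range set by the carbon-only rings of compound 2 and compound 3. No measurement shown here explains these steps.

The compounds shown leave open how much of the change belongs to the amine and how much to the ring nitrogen. An unsubstituted pyridin-3-yl group would separate the two.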